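This account rests on a few compounds, and the source may have more. Where it says the series, first, only, none or still open, it means among the compounds named here.

Measured in a functional assay on MV4-11 cells (Homo sapiens) for antiproliferative activity, read by CCK-8 assay, with a stated time of 72 h; a higher number here means a weaker inhibitor, a lower number a stronger inhibitor:
- compound 1 `Cc1cc(F)cc(C)c1Oc1ccc(C(C)(C)O)cc1-c1cn(C)c(=O)c2[nH]c(C(=O)NCc3ccc(C(=O)NO)cc3)cc12`: 440 nM
- compound 2 `Cn1cc(-c2ccccc2Oc2ccccc2)c2cc(C(=O)NCCCC(=O)NO)[nH]c2c1=O`: 380 nM
- compound 3 `Cn1cc(-c2ccccc2F)c2cc(C(=O)NCc3ccc(C(=O)Nc4ccccc4N)cc3)[nH]c2c1=O`: 230 nM

Compound 2, at 380 nM, lies within the scatter of both compound 1 and compound 3, so the three values do not separate.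

Compound 4 `Cn1cc(-c2ccccc2Oc2ccccc2)c2cc(C(=O)NCc3ccc(C(=O)NO)cc3)[nH]c2c1=O` carries 4-(hydroxycarbamoyl)phenyl in place of 2-(hydroxycarbamoyl)ethyl on a saturated chain carbon bound to an amide-type nitrogen. Going by the values given here, no measured pair isolates this change. Compound 1 also carries 4-(hydroxycarbamoyl)benzyl and gives 440 nM, but it differs from compound 4 elsewhere as well. No step beyond the scatter is therefore expected in this assay, in either direction. The expected step is a 1.2-fold lower number from compound 2 to compound 4 (0.07 log units; within the scatter). For compound 4 the estimated value is 320 nM, with an expected range of 110 nM to 850 nM.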

Compound 4, half-maximal inhibitory concentration: 570 nM
Beside the measured number, compound 4's estimate is 1.8-fold (0.25 log units) below it; low and high end bracket the measured number.
By their numbers in this assay, from the lowest: compounds 3, 2, 1 and 4 (each within the scatter of the next, the first and the last beyond it).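

In this assay the exchange of 3-(hydroxycarbamoyl)propyl for 4-(hydroxycarbamoyl)benzyl gives a 1.5-fold higher number from compound 2 to compound 4 (0.18 log units; within the scatter). Going by these compounds alone, this is the first comparison that isolates one place, and it does not separate the two groups, although the entering group adds a six-membered aromatic ring of carbon only. No evidence bearing on this result is available.

Open, going by these compounds, is how a longer chain ending in hydroxycarbamoyl, or a carboxylic acid in place of hydroxycarbamoyl, would read at this place. Also open, on these data alone, is whether the same exchange reads alike on other cores.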